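The source may hold more compounds than are shown below. What is called first, only, known or untested is meant among the compounds shown, and "the series" means these compounds.

Measured compounds:
- Compound 1, `CNc1nc2cc(Cl)c(Cl)cc2n1COCCO`: > 100000 nM
- Compound 2, `CNc1nc2c(Cl)cc(Cl)cc2n1COCCO`: > 100000 nM
- Compound 3, `Nc1nc2c(Cl)c(Cl)ccc2n1COCCO`: > 100000 nM

In a functional assay on KB cells (Homo sapiens) for inhibition (on this read-out higher numbers stand for weaker inhibition and lower numbers for stronger inhibition), compound 1 gives > 100000 nM, which is a limit of the assay and not a number. Compound 2 likewise gives only a limit in this assay, > 100000 nM. Compound 3 also gives only a limit in this assay, > 100000 nM. Compound 1 therefore cannot be placed above or below its companions: every value shown coincides at the limit of > 100000 nM in this assay, at which 3 of the 3 values shown sit, and no measured step between any two of these compounds exists.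

Compound 4, `OCCOCn1c(Br)nc2cc(Cl)c(Cl)cc21`, has not yet been measured in this assay. It differs from compound 1 by bromo in place of methylamino on an aromatic carbon; in words, bromo in place of methylamino on an aromatic carbon. Among the measured compounds shown here, with no measured step to draw on, the size of this change can only be guessed. Because compound 1 sits at the limit of > 100000 nM in this assay, at which 3 of the 3 values shown sit, compound 4 is expected to remain there as well, with no shift beyond the scatter. The expected step is a number no higher from compound 1 to compound 4 (the limit leaves the size open). The estimate for compound 4 is 100000 nM, between 20000 nM and 500000 nM.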

Compound 4, half-maximal inhibitory concentration: > 100000 nM
Compound 4: only a limit was reported; the forecaster's own chance of this, stated with the estimate: 80%; the middle value sits exactly at the limit.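

Compound 1 and compound 4 both give only a limit in this assay, so the step between them cannot be read: the limit of > 100000 nM in this assay, at which 4 of the 4 values shown sit.

The compounds shown leave open how strongly any of them inhibits in this assay, and therefore which changes to the shared core matter.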